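Hydrazone aryl swap in a urea series: expecting weaker cytotoxicity

A few compounds are considered here, and "the series" means these few. Any claim that something is new, unique, unknown or untested is made for them only; others in the source may bear on it.

Measured compounds:
Compound 1 `COc1ccc(/C=N/NC(=O)Nc2ccc(Oc3ccnc(-c4nncn4CCN(C)C)c3)c(F)c2)c(OC)c1`: 12600 nM
Compound 2 `CN(C)CCn1cnnc1-c1cc(Oc2ccc(NC(=O)N/N=C/c3ccc(F)cc3Cl)cc2F)ccn1`: 1210 nM

Within the data shown here, in a functional assay on U-87MG ATCC cells (Homo sapiens) for cytotoxicity, read by MTT assay, with a stated time of 72 h (a higher number here means a weaker inhibitor, a lower number a stronger inhibitor), compound 2 stands at the lowest of the two numbers, with compound 1 as its only neighbour giving 12600 nM. Among the measured compounds shown here, the one measured step, a 10-fold lower number from compound 1 to compound 2 (1.02 log units; beyond the scatter), came from 2-chloro-4-fluorophenyl in place of 2,4-dimethoxyphenyl on the carbon double-bonded to nitrogen.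

Compound 3 `COc1cc(/C=N/NC(=O)Nc2ccc(Oc3ccnc(-c4nncn4CCN(C)C)c3)c(F)c2)ccc1O` is not yet measured. It differs from compound 2 in that (4-hydroxy-3-methoxyphenyl in place of 2-chloro-4-fluorophenyl on a carbon with a double bond to nitrogen). The entering 4-hydroxy-3-methoxyphenyl shares more with the 2,4-dimethoxyphenyl of compound 1 than with the 2-chloro-4-fluorophenyl of compound 2, so the measured step is expected to reverse in part, with a higher number in this assay expected, though its exact size is uncertain. The expected step is a 5.0-fold higher number from compound 2 to compound 3 (0.70 log units; beyond the scatter). Compound 3 is therefore estimated at 6000 nM, with a range from 2000 nM to 20000 nM.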

Compound 3, half-maximal inhibitory concentration: > 100000 nM
Compound 3: no number, only a limit; the forecaster's own chance of this, stated with the estimate: 5%; middle value at least 16-fold (1.22 log units) from the limit.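

In this assay compound 3 gives a limit and not a number: the limit of > 100000 nM in this assay, at which 1 of the 3 values shown sits. On the carbon with a double bond to nitrogen, the aryl group can therefore move the read-out much further than the first pair showed, with an at least 82-fold higher number from compound 2 to compound 3 (1.91 log units; beyond the scatter). The two oxygen-bearing rings also differ from each other, with an at least 7.9-fold higher number from compound 1 to compound 3 (0.89 log units; beyond the scatter), so swapping the 2-chloro-4-fluorophenyl for an oxygen-bearing ring does not give one fixed result.

On these data alone, how weak compound 3 really is stays unknown, and both steps give only a minimum size. As far as these compounds go, it also remains open whether a 3,4-dimethoxyphenyl on that carbon would fall near compound 1 or near compound 3, which would help separate the role of the free hydroxyl from that of the placing of the oxygens.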